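A Nitro Group on the Core of Compound 1

The source may hold more compounds than are shown below. What is called first, only, known or untested is meant among the compounds shown, and "the series" means these compounds.

In a functional assay on HepG2 cells (Homo sapiens) for antiproliferative activity, read by MTT assay, with a stated time of 72 h (a higher number here means a weaker inhibitor, a lower number a stronger inhibitor), compound 1 `COc1cc(CCc2ccccc2)cc(OC)c1O` gives 7830 nM and compound 2 `COc1cc(CCc2cccc(F)c2)cc(OC)c1O` gives 12400 nM so the two stand level within the scatter, and neither can be placed ahead of the other. Compound 3 `COc1cc(CCc2ccc([N+](=O)[O-])cc2)cc(OC)c1O` has not yet been measured. It departs from compound 1 in one place, with nitro in place of hydrogen on an aromatic carbon, para to a large group (nitro in place of hydrogen on an aromatic carbon). For the measured compounds named here, only one measured step bears on this change: fluoro in place of hydrogen on an aromatic carbon gives a 1.6-fold higher number from compound 1 to compound 2 (0.20 log units; within the scatter) and stays within the scatter. Going by the values given here, that step concerns a different group, and no measured step involves nitro, so it offers only a loose guide. On that single small step, no change beyond the scatter is expected in this assay and no firm direction can be named. The estimate corresponds to an expected 1.3-fold higher number from compound 1 to compound 3 (0.11 log units; within the scatter) and remains a small move. For compound 3 the estimated value is 10000 nM with an expected range from 3500 nM to 30000 nM in this wide span.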

Compound 3, half-maximal inhibitory concentration: 11000 nM
Beside the measured number, compound 3's estimate is 1.1-fold (0.04 log units) below it; the range from low to high includes it.
By their numbers in this assay, from the lowest: compounds 1, 3 and 2 (each within the scatter of the next).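

In this assay nitro in place of hydrogen on this aromatic carbon, para to a large group, gives a 1.4-fold higher number from compound 1 to compound 3 (0.15 log units; within the scatter) and so leaves compound 3 level with compound 1. For the compounds shown here, until now, the only measured change on this outer ring was a single fluoro, with a 1.6-fold higher number from compound 1 to compound 2 (0.20 log units; within the scatter) as its step. The new step shows that a much larger substituent, nitro with its 3 heavy atoms, 2 hydrogen-bond acceptors and no net charge, can also stand at this position without a shift beyond the scatter, although nothing measured here accounts for this result.

All three compounds stand level within the scatter. None of the steps shown marks a group that separates itself in this assay from the hydrogen of compound 1. From the compounds shown here alone, whether an amine, a carboxylic acid or a longer chain on this same aromatic carbon would produce a step beyond the scatter remains open, as does whether nitro would behave the same way elsewhere on the ring.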